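Swapping the Aryl Group on the Triazole Amide

This account rests on a few compounds, and the source may have more. Where it says the series, first, only, none or still open, it means among the compounds named here.

Compound 1 `COc1cc2c(Oc3ccc(NC(=O)c4cn(-c5ccc(Br)cc5)nn4)cc3F)ccnc2cc1OCCCN1CCCC1`: 370 nM
Compound 2 `COc1cc2c(Oc3ccc(NC(=O)c4cn(-c5ccccc5C)nn4)cc3F)ccnc2cc1OCCCN1CCCCC1`: 3230 nM
Compound 3 `COc1cc2c(Oc3ccc(NC(=O)c4cn(-c5ccccc5F)nn4)cc3F)ccnc2cc1OCCCN1CCCCC1`: 2770 nM

These three compounds share one core and were compared in a functional assay on A549 cells (Homo sapiens) for cytotoxicity, read by MTT assay, with a stated time of 72 h; a higher number here means a weaker inhibitor, a lower number a stronger inhibitor. Compound 3 gives the second highest number of the three; its nearest neighbour is compound 2, which sits within the scatter, and its furthest is compound 1, which lies well beyond it. Compound 4 `COc1cc2c(Oc3ccc(NC(=O)c4cn(-c5ccc(Br)cc5)nn4)cc3F)ccnc2cc1OCCCN1CCCCC1` has not yet been measured. Going from compound 3 to compound 4 involves a single change: 4-bromophenyl in place of 2-fluorophenyl on an aromatic nitrogen. Among the compounds with values here, only one measured step touches this part of the molecule, a 1.2-fold lower number from compound 2 to compound 3 (0.07 log units; within the scatter), and it shows that trading one small group for another on that ring left the number essentially unchanged. That step compared two 2-substituted phenyls, whereas compound 4 carries 4-bromophenyl, the same group found in compound 1. Compound 1 and compound 4 differ elsewhere, so their numbers cannot be read as a clean step, yet compound 1 gives a clearly lower number than compound 2 or compound 3. The step of a 3.1-fold lower number from compound 3 to compound 4 (0.49 log units; beyond the scatter) is therefore expected to lower the number, with wide uncertainty. Compound 4 is expected to give about 900 nM in this assay, between 300 nM and 2800 nM.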

Compound 4, half-maximal inhibitory concentration: 230 nM
The estimate for compound 4 lay 3.9-fold (0.59 log units) above the measured number, and the stated range ends above it.
By their numbers in this assay, from the lowest: compounds 4 and 1 (each within the scatter of the next); then compounds 3 and 2 (each within the scatter of the next).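

In this assay the group on the aromatic nitrogen turns out to matter a great deal: a 12-fold lower number from compound 3 to compound 4 (1.08 log units; beyond the scatter) and a 14-fold lower number from compound 2 to compound 4 (1.15 log units; beyond the scatter) are both large, whereas the exchange between the two 2-substituted phenyl groups, a 1.2-fold lower number from compound 2 to compound 3 (0.07 log units; within the scatter), stayed within the scatter. At the other end of the molecule, a 1.6-fold lower number from compound 1 to compound 4 (0.21 log units; within the scatter) also lies within the scatter, so with 4-bromophenyl in place, piperidin-1-yl and pyrrolidin-1-yl cannot be told apart in this assay. Nothing given here explains why 4-bromophenyl goes with so large a step.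

This change replaced the halogen and moved its place on the phenyl ring in a single step, so the compounds shown cannot separate the two; 2-bromophenyl or 4-fluorophenyl would be needed to tell which of them accounts for the step. It also remains open whether bromine itself is needed at all, which a group such as 4-methylphenyl or 4-methoxyphenyl on the same nitrogen would test, and whether a morpholine at the end of the chain would fit in as well as the two amines shown.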